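The compounds below may be only part of what the source reports. "The series", "measured", "known", "first", "only" and "open" are said of these compounds alone.

In this series, compound 1 `CC[C@@H](Nc1c(C#N)c(-c2ccc(-c3ccncc3C)cc2)nc2cnccc12)C(N)=O` reads 2 in a physicochemical assay for lipophilicity, read by HPLC, at pH 7.5 (a lower number here means a more polar compound, a higher number a more lipophilic compound), and compound 2 `CC[C@@H](Nc1c(C#N)c(-c2ccc(-c3ccccc3N(C)C)cc2)nc2cnccc12)C(N)=O` reads 3.2 on the same scale, the higher of the two numbers. Within the data shown here, the one measured step is a number 1.20 log units higher from compound 1 to compound 2 (beyond the scatter) and comes with 2-(dimethylamino)phenyl in place of 3-methylpyridin-4-yl on an aromatic carbon; it is large and beyond the scatter. Compound 3 `CC[C@@H](Nc1c(C#N)c(-c2ccc(-c3cccc(CO)c3)cc2)nc2cnccc12)C(N)=O` is still unmeasured. Its change from compound 2 is 3-(hydroxymethyl)phenyl in place of 2-(dimethylamino)phenyl on an aromatic carbon in one place, with 3-(hydroxymethyl)phenyl in place of 2-(dimethylamino)phenyl, para to a large group. Among the measured compounds shown here, no measured step brings in 3-(hydroxymethyl)phenyl, so the only guide is the swap at this same place, a number 1.20 log units higher from compound 1 to compound 2 (beyond the scatter) when the group now leaving came in. A drop smaller than that step, yet probably beyond the scatter, is expected in this assay for this change. The expected change is a number 0.70 log units lower from compound 2 to compound 3 (beyond the scatter) as estimated here. Compound 3 is estimated at 2.5 with an expected range of 2 to 3 on this scale.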

Compound 3, distribution coefficient: 2
Beside the measured number, compound 3's estimate is 0.50 log units above it, within the range that was stated.
By their numbers in this assay, from the lowest: compounds 1 and 3 (each within the scatter of the next); then compound 2.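

At this place, on an aromatic carbon para to a large group, 3-(hydroxymethyl)phenyl in place of 2-(dimethylamino)phenyl gives in this assay a reading of a number 1.20 log units lower from compound 2 to compound 3 (beyond the scatter) and so matches in size the earlier step of a number 1.20 log units higher from compound 1 to compound 2 (beyond the scatter) in the opposite direction. The second new comparison, no change at the digits printed from compound 1 to compound 3 (within the scatter) with 3-(hydroxymethyl)phenyl in place of 3-methylpyridin-4-yl, shows that two different groups at this place can give the same printed number, and among these three compounds only compound 2 stands apart. Nothing measured here accounts for these numbers.

What 3-(dimethylamino)phenyl or 2-(hydroxymethyl)phenyl would read remains open, so the compounds shown do not separate the effect of the group from that of its place on the phenyl ring. Nor does this assay yet say how a carboxylic acid, a primary amine or a longer chain ending in hydroxyl would read at this same place, or whether any such group would fall outside the span set by these three compounds.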